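The compounds below may be only part of what the source reports. "The series", "measured", "known", "first", "only" and "open" are said of these compounds alone.

Compound 1 (`Cn1cc(-c2cnc3ncnc(NCc4cccc([N+](=O)[O-])c4)c3c2)cn1`) is the starting point in a functional assay on A549 cells (Homo sapiens) for antiproliferative activity, read by MTT assay, with a stated time of 72 h; a higher number here means a weaker inhibitor, a lower number a stronger inhibitor. Compound 1 gives > 100000 nM, which is a limit and not a number. Compound 2 (`Cn1cc(-c2ccc3ncnc(Nc4ccc(F)c(Cl)c4)c3c2)cn1`) likewise gives only a limit, > 100000 nM. Compound 3 (`C#Cc1cccc(Nc2ncnc3ccc(-c4cnn(C)c4)cc23)c1`) gives a true number, 9860 nM. Compound 1 therefore stands with compound 2 at the limit of > 100000 nM in this assay, at which 2 of the 3 values shown sit, while compound 3 goes against that picture.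

Compound 4 (`COc1cccc(CNc2ncnc3ncc(-c4cnn(C)c4)cc23)c1`) keeps the core of compound 1 and changes a single group: methoxy in place of nitro on an aromatic carbon. In words, methoxy takes the place of nitro on an aromatic carbon, turning 3-nitrophenyl into 3-methoxyphenyl.

Going by the values given here, only one measured step bears on this, and only loosely, since it changes a different group: an at least 10-fold lower number from compound 2 to compound 3 (1.00 log units; beyond the scatter). Among the compounds with values here, it shows that one swap can move a compound clear of the limit, but no measured step tests the nitro-to-methoxy change itself. The expected step of an at least 1.2-fold lower number from compound 1 to compound 4 (0.09 log units; that floor lies within the scatter) is therefore small, with at most a slight shift towards a lower number in this assay. For compound 4 the estimated value is 80000 nM, with an expected range from 20000 nM to 150000 nM.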

Compound 4, half-maximal inhibitory concentration: > 100000 nM
Compound 4 was reported as a limit; the forecaster's own chance of this, stated with the estimate: 60%; middle value at least 1.2-fold (0.09 log units) away from the limit.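

In this assay compound 4 gives > 100000 nM, which is a limit; compound 1 also has only a limit, so no step can be read between these two compounds: the limit of > 100000 nM in this assay, at which 3 of the 4 values shown sit.

The compounds shown leave open whether methoxy in place of nitro changes antiproliferative activity at all.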